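Isatin-type series: aryl swap at the fused ring position

The source may report more compounds than this note shows. Statements on the series, on what has been measured and on what is new or still open speak of the compounds shown alone.

Three compounds of the shared core have a value in a functional assay on HepG2 cells (Homo sapiens) for antiproliferative activity, read by MTT assay, with a stated time of 48 h; a lower number here means a stronger inhibitor, a higher number a weaker inhibitor. Compound 1 `COc1ccc(-c2ccc3c(c2)C(=O)C(=O)N3Cc2cccc(Cl)c2)cc1` gives 320 nM. Compound 2 `COc1ccc(-c2ccc3c(c2)C(=O)C(=O)N3Cc2ccc(OC)c(OC)c2)cc1` gives 1350 nM. Compound 3 `COc1ccc(CN2C(=O)C(=O)c3cc(-c4ccc(C(C)(C)C)cc4)ccc32)cc1` gives 4580 nM, the highest of the three numbers, with compound 2 nearest and compound 1 furthest from it. Among the measured compounds shown here, the only single-place step so far is a 4.2-fold higher number from compound 1 to compound 2 (0.63 log units; beyond the scatter), which concerns the group on the saturated chain carbon bound to the amide-type nitrogen, not the aromatic carbon altered here.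

Compound 4 `COc1ccc(CN2C(=O)C(=O)c3cc(-c4ccncc4)ccc32)cc1` differs from compound 3 in one place: pyridin-4-yl in place of 4-(tert-butyl)phenyl on an aromatic carbon. For the measured compounds named here, no measured step changes this aromatic position, so no step bears directly on the expected size or direction. What the numbers do show is that compound 3, carrying 4-(tert-butyl)phenyl at this position, sits well above compound 1 and compound 2, which carry 4-methoxyphenyl there, but those pairs also differ at the chain carbon, so they give only a loose indication.

For compound 4 the expected value in this assay is 2500 nM, within a range of 800 nM to 8000 nM. The estimated step of a 1.8-fold lower number from compound 3 to compound 4 (0.26 log units; within the scatter) is therefore a modest lowering, with the outcome open in either direction.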

Compound 4, half-maximal inhibitory concentration: > 10000 nM
Compound 4 was reported as a limit; the forecaster's own chance of this, stated with the estimate: 10%; middle value at least 4.0-fold (0.60 log units) from the limit.
By their numbers in this assay, from the lowest: compound 1; then compound 2; then compound 3. At a limit, above all of these: compound 4.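

In this assay compound 4 gives > 10000 nM, which is a limit of the assay and not a number: the limit of > 10000 nM in this assay, at which 1 of the 4 values shown sits. Among the compounds shown here, this is the first single-place reading at this aromatic carbon, and replacing 4-(tert-butyl)phenyl with pyridin-4-yl gives an at least 2.1-fold higher number from compound 3 to compound 4 (0.33 log units; beyond the scatter), so the aryl group at this position does affect the result. With one end of the step at a limit, the printed size is only a minimum and the full size of the change cannot be read, though its direction is clear.

The change removes the tert-butyl group and also puts a nitrogen into the aromatic ring, and these two parts cannot be separated with the compounds shown, so a plain phenyl group at this carbon would be the obvious next reading. Also open, from the compounds shown here alone, is whether the ring nitrogen matters at its present place, which pyridin-3-yl would test, and whether a substituted phenyl carrying an amine or a carboxylic acid at this aromatic carbon would stay within the measurable range.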